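A dichlorophenyl amide in place of a fluoro-iodophenyl amide

The source may hold more compounds than are shown below. What is called first, only, known or untested is meant among the compounds shown, and "the series" means these compounds.

Compound 1 `O=C(Nc1ccc(S(=O)(=O)Nc2ccccc2)cc1)c1ccc(I)cc1F` carries a 2-fluoro-4-iodophenyl group on the carbonyl carbon of its amide. In a functional assay on HEK293 cells for agonist activity at probable G-protein coupled receptor 27 (Homo sapiens), read by a luciferase reporter and beta-arrestin recruitment, with a stated time of 10 min (a higher number here means that more compound is needed for the effect, a lower number that less compound is needed), compound 1 gives 5130 nM, the highest number among the three measured compounds. Compound 2 `O=C(Nc1ccc(S(=O)(=O)Nc2ccccc2)cc1)c1ccc(Cl)cc1F` differs from it only by chloro in place of iodo on an aromatic carbon and gives 3980 nM; the step of a 1.3-fold lower number from compound 1 to compound 2 (0.11 log units; within the scatter) is within the scatter, so the two compounds cannot be ranked against each other. Compound 3 `Cc1ccccc1NS(=O)(=O)c1ccc(NC(=O)c2ccc(Cl)cc2Cl)cc1`, which carries a 2,4-dichlorophenyl group and a methyl on the sulfonamide aryl ring, gives 1230 nM, a number beyond the scatter from compound 1.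

Compound 4 `O=C(Nc1ccc(S(=O)(=O)Nc2ccccc2)cc1)c1ccc(Cl)cc1Cl` is not yet measured. Its difference from compound 1 is 2,4-dichlorophenyl in place of 2-fluoro-4-iodophenyl on a carbonyl carbon. Among the measured compounds shown here, no measured step covers exactly this exchange; the step from compound 1 to compound 2 shows that swapping one halogen for another at the same position changed little, while compound 3 shows that a 2,4-dichlorophenyl amide can sit at a lower number, though with a second change elsewhere. A modest move toward lower numbers is therefore expected for compound 4, with a step of a 2.1-fold lower number from compound 1 to compound 4 (0.31 log units; beyond the scatter), giving an estimate of 2500 nM in this assay, within a range of 900 nM to 7000 nM.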

Compound 4, half-maximal effective concentration: 457 nM
The estimate for compound 4 lay 5.5-fold (0.74 log units) above the measured number; the measured number lies below the stated range.
By their numbers in this assay, from the lowest: compound 4; then compound 3; then compounds 2 and 1 (each within the scatter of the next).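

On the carbonyl carbon of the amide, 2,4-dichlorophenyl in place of 2-fluoro-4-iodophenyl brings an 11-fold lower number from compound 1 to compound 4 (1.05 log units; beyond the scatter) in this assay, so the halogens on this ring can matter far more than a 1.3-fold lower number from compound 1 to compound 2 (0.11 log units; within the scatter) alone suggested. Most of that gain appears when the fluoro on this ring gives way to a second chloro, which gives an 8.7-fold lower number from compound 2 to compound 4 (0.94 log units; beyond the scatter) and contrasts with the chloro-for-iodo exchange, whose step could not be ranked. Hydrogen in place of methyl on an aromatic carbon also counts, giving a 2.7-fold lower number from compound 3 to compound 4 (0.43 log units; beyond the scatter) and showing that the 2,4-dichlorophenyl amide does not need the methyl of compound 3 to reach a low number in this series.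

No measurement shown explains why these exchanges move the number. On these data alone, it also remains open whether a group other than a halogen on this ring, such as a methoxy or a nitrile, would keep the number as low as in compound 4 or lower it further.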